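Dropping the Hydroxy from the Pendant Phenyl Ring

A few compounds are considered here, and "the series" means these few. Any claim that something is new, unique, unknown or untested is made for them only; others in the source may bear on it.

Three compounds share one core and differ only in the aryl group hanging from it. Compound 1 `Cc1nc2c3ccccc3ccc2c2nc3c(ccc4ccccc43)c(-c3cccc([N+](=O)[O-])c3)c12` carries a 3-nitrophenyl group and in a functional assay, with a stated time of 90 s (a lower number here means a stronger inhibitor, a higher number a weaker inhibitor), gives 157 ug/mL. Compound 2 `Cc1nc2c3ccccc3ccc2c2nc3c(ccc4ccccc43)c(-c3ccccc3Cl)c12` carries a 2-chlorophenyl group and in this assay gives 170 ug/mL. Compound 3 `Cc1nc2c3ccccc3ccc2c2nc3c(ccc4ccccc43)c(-c3ccc(O)cc3)c12` carries a 4-hydroxyphenyl group and in this assay gives 99 ug/mL, the smallest of the three numbers shown, though the step of a 1.6-fold lower number from compound 1 to compound 3 (0.20 log units; within the scatter) and the step of a 1.7-fold lower number from compound 2 to compound 3 (0.23 log units; within the scatter) both stay within the scatter, so the three compounds cannot be ranked against one another.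

Compound 4 `Cc1nc2c3ccccc3ccc2c2nc3c(ccc4ccccc43)c(-c3ccccc3)c12` is compound 3 with the hydroxy taken away: hydrogen in place of hydroxy on an aromatic carbon. Among the compounds with values here, no measured pair removes exactly this group. The closest guides are the swaps of the whole pendant ring already shown; a 1.1-fold higher number from compound 1 to compound 2 (0.03 log units; within the scatter), a 1.6-fold lower number from compound 1 to compound 3 (0.20 log units; within the scatter) and a 1.7-fold lower number from compound 2 to compound 3 (0.23 log units; within the scatter) all lie within the scatter, so changing that ring has so far moved this assay little. The step expected here, a 1.2-fold higher number from compound 3 to compound 4 (0.08 log units; within the scatter), is therefore small, with no direction that can be told apart from the scatter. Compound 4 is estimated to give 120 ug/mL in this assay, within a range from 60 ug/mL to 240 ug/mL.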

Compound 4, half-maximal inhibitory concentration: 188 ug/mL
The estimate for compound 4 lay 1.6-fold (0.19 log units) below the measured number; the measured number falls inside the stated range.
By their numbers in this assay, from the lowest: compounds 3, 1, 2 and 4 (each within the scatter of the next).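

With the hydroxy gone, compound 4 has a bare phenyl ring, and a 1.9-fold higher number from compound 3 to compound 4 (0.28 log units; within the scatter) shows that in this assay this group on an aromatic carbon, para to a large group, cannot be told apart from hydrogen. The earlier compounds shown here only swapped one substituted ring for another, whereas compound 4 provides the unsubstituted reference, and the two other groups also stay within the scatter of it: a 1.1-fold higher number from compound 2 to compound 4 (0.04 log units; within the scatter) for the chloro and a 1.2-fold higher number from compound 1 to compound 4 (0.08 log units; within the scatter) for the nitro. No independent measurement is available to explain why these steps are so small.

Each pendant ring here is a phenyl ring carrying one group or none, so these four compounds cannot show whether this position responds to anything at all or simply tolerates whatever is placed there. An amine, a carboxylic acid or a longer chain such as butoxy on this ring, or a pyridine in place of the phenyl ring, could show whether any change here moves the number beyond the scatter.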